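This account rests on a few compounds, and the source may have more. Where it says the series, first, only, none or still open, it means among the compounds named here.

Among the compounds with values here, in a functional assay on K562 cells (Homo sapiens) for antiproliferative activity, read by MTT assay, with a stated time of 24 h (a lower number here means a stronger inhibitor, a higher number a weaker inhibitor), three compounds built on a shared core have numbers so far: compound 1 `COC(=O)c1scc(-c2ccc(NC(=O)c3ccc4ccccc4c3)cc2)c1OC` gives 10300 nM, compound 2 `COC(=O)c1scc(-c2ccc(NC(=O)c3ccccn3)cc2)c1OC` gives 24200 nM, and compound 3 `COC(=O)c1scc(-c2ccc(NC(=O)c3cccc(C(F)(F)F)c3)cc2)c1OC` gives 6130 nM. Compound 3 sits close to compound 1, as the measured step shows: a 1.7-fold lower number from compound 1 to compound 3 (0.23 log units; within the scatter). Compound 2 lies further off, with a 2.3-fold higher number from compound 1 to compound 2 (0.37 log units; beyond the scatter) and a 3.9-fold lower number from compound 2 to compound 3 (0.60 log units; beyond the scatter).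

Within the data shown here, the next compound, compound 4 `COC(=O)c1scc(-c2ccc(NC(=O)c3ccc(F)c(Cl)n3)cc2)c1OC`, has no measurement yet. It changes only the group on a carbonyl carbon: 6-chloro-5-fluoropyridin-2-yl in place of 3-(trifluoromethyl)phenyl on a carbonyl carbon. Compound 2 is the closest measured match, since it carries pyridin-2-yl in that place, and 6-chloro-5-fluoropyridin-2-yl is that same group with chloro and fluoro added. The step that bears most directly is therefore a 3.9-fold lower number from compound 2 to compound 3 (0.60 log units; beyond the scatter), read in reverse. Among the measured compounds shown here, no measured compound shows what the chloro and fluoro additions do, so compound 4 need not fall all the way back to compound 2, and a position between compound 3 and compound 2 seems the fair guess. In this assay the expected step is modest and towards a higher number: a 2.1-fold higher number from compound 3 to compound 4 (0.33 log units; beyond the scatter). For compound 4 the estimated value is 13000 nM, with an expected range from 6000 nM to 26000 nM.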

Compound 4, half-maximal inhibitory concentration: 8250 nM
Estimate against measurement, compound 4: 1.6-fold (0.20 log units) above, and the stated range covers the measured number.
By their numbers in this assay, from the lowest: compounds 3, 4 and 1 (each within the scatter of the next); then compound 2.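

In this assay, a pyridine ring on the carbonyl carbon does not by itself tie a compound to the high number of compound 2: carrying chloro and fluoro on that ring gives a 2.9-fold lower number from compound 2 to compound 4 (0.47 log units; beyond the scatter). The substituted ring also cannot be told apart from the two larger-looking carbon-only groups, with a 1.3-fold higher number from compound 3 to compound 4 (0.13 log units; within the scatter) and a 1.2-fold lower number from compound 1 to compound 4 (0.10 log units; within the scatter), both inside the usual scatter, so 3-(trifluoromethyl)phenyl, naphthalen-2-yl and 6-chloro-5-fluoropyridin-2-yl all give numbers of the same order at this position, and only the unsubstituted pyridin-2-yl of compound 2 stands apart from the other three. What lies behind the difference made by the two added atoms cannot be said, as no measurement on the mechanism accompanies these numbers.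

Whether the chloro, the fluoro or only the two together account for the step from compound 2 stays open, as neither appears alone on the pyridine ring. Also open, on these data alone, is what a different kind of group would do on the same ring or on the carbonyl carbon, such as an amine, a carboxylic acid or an open alkyl chain.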